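Swapping a Sulfonamide for a Methylsulfone on a Shared Core

The source may hold more compounds than are shown below. What is called first, only, known or untested is meant among the compounds shown, and "the series" means these compounds.

Within the data shown here, compound 2 `NS(=O)(=O)c1ccc(Nc2ncc(F)c(Nc3nc4ccc(Cl)cc4s3)n2)cc1` is the only compound here with a numbered result: in a functional assay on PC-3 cells (Homo sapiens) for antiproliferative activity, read by MTT assay, with a stated time of 48 h (on this read-out lower numbers stand for stronger inhibition and higher numbers for weaker inhibition), compound 2 gives 1430 nM. Compound 1 `Cc1ccc2nc(Nc3nc(Nc4ccc(S(C)(=O)=O)cc4)ncc3F)sc2c1` reaches only > 50000 nM in this assay, which is a limit of the assay rather than a measured number (the limit of > 50000 nM in this assay, at which 1 of the 2 values shown sits). Compound 3 `CS(=O)(=O)c1ccc(Nc2ncc(F)c(Nc3nc4ccc(Cl)cc4s3)n2)cc1` differs from compound 2 in one place: methyl in place of amino on a sulfonyl sulfur. Among the measured compounds shown here, no measured pair shows this exact change. Compound 3 is expected to be weaker, with a step of a 5.6-fold higher number from compound 2 to compound 3 (0.75 log units; beyond the scatter) that is expected to lie beyond the usual scatter. The estimated value for compound 3 in this assay is 8000 nM, with a range from 2000 nM to 50000 nM.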

Compound 3, half-maximal inhibitory concentration: > 50000 nM
Compound 3 ended at the assay's limit; the forecaster's own chance of this, stated with the estimate: 30%; at least 6.2-fold (0.79 log units) between middle value and limit.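

On the sulfonyl sulfur, the change from amino to methyl now has a measured result: in this assay it gives an at least 34-fold higher number from compound 2 to compound 3 (1.54 log units; beyond the scatter), so the activity seen with the sulfamoyl group of compound 2 does not carry over to the methylsulfonyl group of compound 3. The value of compound 3, > 50000 nM, is a limit of the assay. The step for chloro in place of methyl on an aromatic carbon cannot be read: the limit of > 50000 nM in this assay, at which 2 of the 3 values shown sit.

Going by these compounds, it remains open whether a methylamino group on the sulfonyl sulfur would keep the activity of compound 2. The same question applies to a carboxylic acid in place of the sulfamoyl group.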